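Two fluorophenyl ureas and a longer relative

The compounds below may be only part of what the source reports. "The series", "measured", "known", "first", "only" and "open" are said of these compounds alone.

Measured in a functional assay on NCI-H460 cells (Homo sapiens) for inhibition, read by MTT assay, with a stated time of 72 h; a higher number here means a weaker inhibitor, a lower number a stronger inhibitor:
- Compound 1 `COc1cc(NC(C)CCCNC(=O)Nc2cccc(F)c2)c2ncccc2c1` gives 24000 nM
- Compound 2 `COc1cc(NC(C)CCCNC(=O)Nc2ccc(F)cc2)c2ncccc2c1` gives 26000 nM

Both numbers are high on this scale, which marks weak inhibitors, and they lie within the scatter of each other. Compound 2 therefore stands level with compound 1, and neither can be ranked above the other.

Compound 3 `COc1cc(NC(C)CCCNC(=O)NNC(=O)Nc2cccc(F)c2)c2ncccc2c1` differs from compound 2 by ((3-fluorophenyl)carbamoyl)amino in place of 4-fluorophenyl on an amide-type nitrogen. Within the data shown here, only one measured step bears on this change: a 1.1-fold higher number from compound 1 to compound 2 (0.03 log units; within the scatter). That step swaps one fluorophenyl group for another, so it offers only weak guidance for a larger replacement. Among the measured compounds shown here, no measured pair shows a group of this kind entering, so the expectation is loose. With no evidence for a direction, no shift beyond the scatter is expected in this assay, although the range must stay wide. The estimate amounts to an expected 1.0-fold lower number from compound 2 to compound 3 (0.02 log units; within the scatter) for the change. Compound 3 is expected to give about 25000 nM (estimated range 8000 nM to 70000 nM).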

Compound 3, half-maximal inhibitory concentration: 50000 nM
Compound 3: the middle estimate sits 2.0-fold (0.30 log units) below what was measured; measured number inside the range.
By their numbers in this assay, from the lowest: compounds 1, 2 and 3 (each within the scatter of the next, the first and the last beyond it).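

In this assay, replacing 3-fluorophenyl with ((3-fluorophenyl)carbamoyl)amino on the amide-type nitrogen gives a 2.1-fold higher number from compound 1 to compound 3 (0.32 log units; beyond the scatter) and makes compound 3 a modestly weaker inhibitor than compound 1. Replacing 4-fluorophenyl with the same larger group gives a 1.9-fold higher number from compound 2 to compound 3 (0.28 log units; within the scatter) so compound 3 cannot be separated from compound 2, and the effect of this change depends on which of the two close relatives serves as the reference. The larger group brings no gain in inhibition at this position, and nothing available gives a reason for the shift.

From the compounds shown here alone, it remains open whether a simple amine or a carboxylic acid in place of the fluorophenyl end would move the number in either direction, and so whether any group at this position can turn these weak inhibitors into stronger ones. Going by these compounds, it is also open whether a 4-fluorophenyl end on the longer group would read the same as the 3-fluorophenyl end of compound 3.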